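The source may report more compounds than this note shows. Statements on the series, on what has been measured and on what is new or still open speak of the compounds shown alone.

Compound 1 `Cc1noc(-c2cc3cc(F)ccc3[nH]2)n1` gives 18100 nM in a functional assay on COLO 320 cells (Homo sapiens) for antiproliferative activity, read by WST assay, with a stated time of 72 h; a higher number here means a weaker inhibitor, a lower number a stronger inhibitor. Compound 2 `Cc1noc(-c2cc3cc(Cl)ccc3[nH]2)n1` gives 19500 nM in this assay. Compound 3 `COc1ccc(-c2noc(-c3cc4cc(F)ccc4[nH]3)n2)cc1` gives 14800 nM in this assay.

Compound 1 and compound 3 share a core that differs in one part; how the two cores differ is not broken down here. Their values fall within the scatter of each other. From compound 1 to compound 2 the change chloro in place of fluoro on an aromatic carbon gave a 1.1-fold higher number from compound 1 to compound 2 (0.03 log units; within the scatter). Compound 4 `COc1ccc(-c2noc(-c3cc4cc(Cl)ccc4[nH]3)n2)cc1`, not yet measured, carries the same change against compound 3: chloro in place of fluoro on an aromatic carbon. Because a 1.1-fold higher number from compound 1 to compound 2 (0.03 log units; within the scatter) stayed within the scatter, the step from compound 3 to compound 4 in this assay is expected to be a 1.1-fold higher number from compound 3 to compound 4 (0.03 log units; within the scatter), resting only on that one earlier pair. Compound 4 is therefore estimated at 16000 nM, likely between 8000 nM and 32000 nM.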

Compound 4, half-maximal inhibitory concentration: 9600 nM
Compound 4: the middle estimate sits 1.7-fold (0.22 log units) above what was measured; low and high end bracket the measured number.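

In this assay, chloro in place of fluoro on an aromatic carbon gave a 1.5-fold lower number from compound 3 to compound 4 (0.19 log units; within the scatter). Set beside the earlier pair, the two steps do not differ by more than repeat measurements would: the same change on two cores in this assay, a 1.1-fold higher number (0.03 log units; within the scatter) from compound 1 to compound 2 and a 1.5-fold lower number (0.19 log units; within the scatter) from compound 3 to compound 4, 1.7-fold (0.22 log units) apart, within the scatter of two such steps. In these two pairs the change therefore carried from one core to the other without any step standing out from the scatter, but two pairs cannot show that this would hold on other cores, and neither step shows a real difference between chloro and fluoro.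

The compounds shown leave open whether a different group on this aromatic carbon, such as an amine or a carboxylic acid, would move the number beyond the scatter.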